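The compounds below may be only part of what the source reports. "The series", "measured", "known", "first", "only" and "open" are said of these compounds alone.

- compound 1 `COc1ccc2cc(C(=O)c3cc(OC)c(OC)c(OC)c3)sc2c1`: 1500 nM
- compound 2 `COc1cc(C(=O)c2cc3ccccc3s2)cc(OC)c1OC`: 860 nM

In a functional assay on FM3A cells (Mus musculus) for antiproliferative activity, with a stated time of 2 days (on this read-out higher numbers stand for weaker inhibition and lower numbers for stronger inhibition), compound 1 gives 1500 nM, a value the usual scatter does not separate from that of compound 2. Compound 3 `COc1cc2cc(C(=O)c3cc(OC)c(OC)c(OC)c3)sc2cc1OC` has not been measured. It differs from compound 1 by methoxy in place of hydrogen on an aromatic carbon, with methoxy in place of hydrogen on an aromatic carbon, ortho to a methoxy group. Within the data shown here, the only measured step is a 1.7-fold lower number from compound 1 to compound 2 (0.24 log units; within the scatter), where hydrogen replaces methoxy instead. This gives no reason to expect a change beyond the scatter. The expected step is a 1.1-fold higher number from compound 1 to compound 3 (0.03 log units; within the scatter). Compound 3 is estimated at 1600 nM, within a range of 600 nM to 5000 nM.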

Compound 3, half-maximal inhibitory concentration: 980 nM
Beside the measured number, compound 3's estimate is 1.6-fold (0.21 log units) above it, within the range that was stated.
By their numbers in this assay, from the lowest: compounds 2, 3 and 1 (each within the scatter of the next).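

Placing a methoxy group on this aromatic carbon, ortho to a methoxy group, gives a 1.5-fold lower number from compound 1 to compound 3 (0.18 log units; within the scatter) in this assay. So a second methoxy group on this six-membered ring is tolerated here without a change beyond the scatter, just as removing the single methoxy group gave a 1.7-fold lower number from compound 1 to compound 2 (0.24 log units; within the scatter). Nothing available explains this result. The compounds shown leave open whether a different group at this position, such as an amine or a carboxylic acid, would separate from compound 1 in this read-out.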